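Sulfonyl aryl change on the compound 3 scaffold

The source may hold more compounds than are shown below. What is called first, only, known or untested is meant among the compounds shown, and "the series" means these compounds.

Measured values
- compound 1 (`CCn1cc(C(=O)O)c(=O)c2cc(F)c(N3CCN(C(=N)NS(=O)(=O)c4ccc(C(F)(F)F)cc4)CC3)cc21`) at 32 nM
- compound 2 (`N=C(NS(=O)(=O)c1ccccc1)N1CCN(c2cc3c(cc2F)c(=O)c(C(=O)O)cn3C2CC2)CC1`) at 32 nM
- compound 3 (`CCn1cc(C(=O)O)c(=O)c2cc(F)c(N3CCN(C(=N)NS(=O)(=O)c4ccccc4Cl)CC3)cc21`) at 32 nM

Compound 3 stands at 32 nM in a functional assay on HeLa cells (Homo sapiens) for antiproliferative activity, read by MTT assay, with a stated time of 72 h (a higher number here means a weaker inhibitor, a lower number a stronger inhibitor), and shares that value with compound 1 and compound 2, so the numbers do not separate the three. Compound 4 (`CCn1cc(C(=O)O)c(=O)c2cc(F)c(N3CCN(C(=N)NS(=O)(=O)c4ccccc4)CC3)cc21`) has hydrogen in place of chloro on an aromatic carbon, ortho to a large group (hydrogen in place of chloro on an aromatic carbon), which turns 2-chlorophenyl to phenyl. Among the compounds with values here, the only measured step on this aryl group is no change at the digits printed from compound 1 to compound 3 (within the scatter) for 2-chlorophenyl in place of 4-(trifluoromethyl)phenyl, and it shows no sensitivity to that exchange. Compound 2 also bears phenylsulfonyl, on a core of its own, and gives 32 nM in this assay as well. Within the data shown here, no measured pair isolates the loss of chloro itself, so the expectation rests on one step only. The estimate is therefore no change at the digits printed from compound 3 to compound 4 (within the scatter) in this assay, with nothing expected beyond the scatter in either direction. For compound 4 the expected value is 32 nM (estimated range 14 nM to 75 nM).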

Compound 4, half-maximal inhibitory concentration: 32 nM
Compound 4: the middle estimate sits on the measured number at the digits printed; the range from low to high includes it.
By their numbers in this assay, from the lowest: compounds 1, 2, 3 and 4 (each within the scatter of the next).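

Hydrogen in place of chloro gives no change at the digits printed from compound 3 to compound 4 (within the scatter) in this assay as the first pair to isolate that exchange on an aromatic carbon, ortho to a large group. Phenyl also reads level with 4-(trifluoromethyl)phenyl, with no change at the digits printed from compound 1 to compound 4 (within the scatter) on the same core, so neither substituent is separated from hydrogen on this sulfonyl aryl group. Away from this position, the phenylsulfonyl pair gives no change at the digits printed from compound 2 to compound 4 (within the scatter) for ethyl in place of cyclopropyl on the aromatic nitrogen, which extends the same level reading to that site.

Open, going by these compounds, is whether a methoxy group or an amine on this phenyl, or a longer chain such as butyl on the aromatic nitrogen, would move the value at all. Nothing available accounts for the level values across these four compounds.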